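The source may report more compounds than this note shows. Statements on the series, on what has been measured and on what is new or still open speak of the compounds shown alone.

The measured compounds:
compound 1, `c1ccc(-c2cn3ccnc3c(-c3ccc4ncn(C5CCCCC5)c4c3)n2)cc1`: in a functional assay on BT-549 cells (Homo sapiens) for inhibition, read by sulforhodamine B assay, with a stated time of 48 h, tested at 10 uM (a higher number here means more inhibition at the concentration tested (going by the name of the read-out), a lower number less inhibition), compound 1 gives 57.1%
compound 2, `COc1ccc(-c2cn3ccnc3c(-c3ccc4ncn(C5CCCCC5)c4c3)n2)cc1`: in this assay compound 2 gives 68.9%
compound 3, `Fc1ccc(-c2cn3ccnc3c(-c3ccc4ncn(C5CCCCC5)c4c3)n2)cc1`: in this assay compound 3 gives 20.3%

Compound 3 stands lowest of the three in this assay. Its nearest neighbour is compound 1, reached by a number 36.8 percentage points lower from compound 1 to compound 3 (beyond the scatter), and the step of a number 48.6 percentage points lower from compound 2 to compound 3 (beyond the scatter) separates it from compound 2. The step of a number 11.8 percentage points higher from compound 1 to compound 2 (beyond the scatter) between the two higher compounds is modest beside these.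

Compound 4, `Brc1ccc(-c2cn3ccnc3c(-c3ccc4ncn(C5CCCCC5)c4c3)n2)cc1`, has not been measured. It differs from compound 3 in one place: bromo in place of fluoro on an aromatic carbon. Going by the values given here, no measured step exchanges one halogen for another, so nothing bears on this change directly. What the numbers do show is that the fluoro of compound 3 stands far below both the hydrogen of compound 1 and the methoxy of compound 2, through a number 36.8 percentage points lower from compound 1 to compound 3 (beyond the scatter) and a number 48.6 percentage points lower from compound 2 to compound 3 (beyond the scatter). Whether a bromo stays near the fluoro or returns toward the hydrogen cannot be read from these three. The expectation for compound 4 is therefore a step of a number 14.7 percentage points higher from compound 3 to compound 4 (beyond the scatter) in this assay, upward but uncertain, with the hydrogen of compound 1 as a loose upper anchor. Compound 4 is estimated at 35%, with a range from 10% to 65%.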

Compound 4, a percentage reported as inhibition, at one concentration (the size of the read-out at that concentration, not a potency): 35.1%
The estimate for compound 4 lay 0.1 percentage points below the measured number; the measured number falls inside the stated range.
By their numbers in this assay, from the lowest: compound 3; then compound 4; then compound 1; then compound 2.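

In this assay, going by these compounds alone, the change from 4-fluorophenyl to 4-bromophenyl gives the first comparison of one halogen with another at this position, and a number 14.8 percentage points higher from compound 3 to compound 4 (beyond the scatter) shows that the two halogens are not interchangeable here. A halogen at this position does not by itself restore the level of the hydrogen or methoxy compounds, since a number 22 percentage points lower from compound 1 to compound 4 (beyond the scatter) and a number 33.8 percentage points lower from compound 2 to compound 4 (beyond the scatter) leave the bromo below both, and among the four compounds shown both halogens lie below hydrogen and methoxy, with no compound going against this. Nothing available on these compounds accounts for this order.

Going by these compounds, whether a chloro at the same place would fall among the other two halogens, and whether an amine or a carboxylic acid para to the same large group would reach or pass the methoxy of compound 2, stays open. The numbers in this assay are also readings at one concentration in one cell line, so they leave open how these differences would appear as potencies or in other cells.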